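This account rests on a few compounds, and the source may have more. Where it says the series, first, only, none or still open, it means among the compounds named here.

Working notes on the series. In a functional assay for inhibition (a higher number here means a weaker inhibitor, a lower number a stronger inhibitor), compound 1 `CC(C)(C)c1cc(-c2cc(=O)c3ccc(OCC(=O)O)cc3o2)cc(C(C)(C)C)c1O` gives 3000 nM; 100 nM (2 entries), and the several entries of compound 1 in this assay, 3000 nM; 100 nM (2 entries) lie far apart. Compound 2 `CCCCCCOc1ccc2c(=O)cc(-c3cc(C(C)(C)C)c(O)c(C(C)(C)C)c3)oc2c1` gives 5000 nM in this assay. That is the only number shown for compound 2, and one further entry for it gives no single number. Its position therefore rests on thin ground.

The next compound is compound 3 `COc1ccc2c(=O)cc(-c3cc(C(C)(C)C)c(O)c(C(C)(C)C)c3)oc2c1`, still to be measured. The change from compound 2 is hydrogen in place of pentyl on a saturated chain carbon bound to an oxygen on an aromatic ring, which shortens hexyloxy to methoxy: hydrogen in place of pentyl on a saturated chain carbon bound to an oxygen on an aromatic ring.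

Going by the values given here, no measured step covers this change, and compounds 1 and 2 differ in more than this one place. No step beyond the scatter is therefore expected in this assay, with no firm direction. The expected change is a 1.4-fold lower number from compound 2 to compound 3 (0.15 log units; within the scatter). The range is kept wide, as compound 1 shows with 3000 nM; 100 nM (2 entries) how far entries of one compound can part. For compound 3 the estimated value is 3500 nM, with an expected range of 600 nM to 20000 nM.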

Compound 3, half-maximal inhibitory concentration: 1000 nM
The estimate for compound 3 lay 3.5-fold (0.54 log units) above the measured number; measured number inside the range.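

In this assay, going by these compounds alone, shortening hexyloxy to methoxy comes with a 5.0-fold lower number from compound 2 to compound 3 (0.70 log units; beyond the scatter), the first step that covers this position. The length of the chain on this oxygen therefore matters in this assay: of the two chains compared, methoxy carries the lower number, and the change removes only pentyl, with no hydrogen-bond donor, hydrogen-bond acceptor or net charge leaving or entering. The step rests on a single pair, with one number for each compound and a further entry for compound 2 that gives no single number, so its size stays provisional, and entries of one compound can part widely here: the several entries of compound 1 in this assay, 3000 nM; 100 nM (2 entries)

The two chains compared leave open whether the number moves steadily with chain length, as an ethoxy or butoxy group at this place would show, or changes only at the shortest chain. Also open, as far as these compounds go, is how a chain ending in an amine or an amide would compare with methoxy on the same core.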